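Cyclohexyl replaces 4-fluorobenzyl on the amide nitrogen

The source may hold more compounds than are shown below. What is called first, only, known or untested is meant among the compounds shown, and "the series" means these compounds.

Three measured compounds share one core and differ only in the group on the amide-type nitrogen. Compound 1 `O=C(Nc1ccccc1)c1cc(Oc2ccc(/C=C/c3ccncc3)cc2)ccn1` carries a phenyl there; in a functional assay on HepG2 cells (Homo sapiens) for antiproliferative activity, read by CCK-8 assay, with a stated time of 48 h (a higher number here means a weaker inhibitor, a lower number a stronger inhibitor), compound 1 gives > 100000 nM, which is a limit of the assay rather than a number. Compound 2 `COc1ccc(NC(=O)c2cc(Oc3ccc(/C=C/c4ccncc4)cc3)ccn2)cc1` carries a 4-methoxyphenyl, and in this assay compound 2 gives > 100000 nM, again a limit. Among the compounds with values here, compound 3 `O=C(NCc1ccc(F)cc1)c1cc(Oc2ccc(/C=C/c3ccncc3)cc2)ccn1` carries a 4-fluorobenzyl, and in this assay compound 3 gives 37200 nM, the only number among the three. The step of an at least 2.6-fold lower number from compound 1 to compound 3 (0.42 log units; beyond the scatter) and the step of an at least 2.6-fold lower number from compound 2 to compound 3 (0.42 log units; beyond the scatter) both favour compound 3, though because the limit of > 100000 nM in this assay, at which 2 of the 3 values shown sit, their full size cannot be read. The step that the two limits leave unreadable from compound 1 to compound 2 tells nothing.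

Compound 4 `O=C(NC1CCCCC1)c1cc(Oc2ccc(/C=C/c3ccncc3)cc2)ccn1` is not yet measured. It differs from compound 3 by cyclohexyl in place of 4-fluorobenzyl on an amide-type nitrogen. Within the data shown here, every measured step concerns this same nitrogen, and the one readable number stands with 4-fluorobenzyl; no measured pair tests a non-aromatic ring in that place. Compound 4 is therefore expected to give a step of a 1.3-fold higher number from compound 3 to compound 4 (0.13 log units; within the scatter) that stays within the scatter. For compound 4 the estimate in this assay is 50000 nM, expected to fall between 15000 nM and 150000 nM.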

Compound 4, half-maximal inhibitory concentration: 22400 nM
Estimate against measurement, compound 4: 2.2-fold (0.35 log units) above; the measured number falls inside the stated range.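

In this assay, the change from the aromatic 4-fluorobenzyl to the non-aromatic cyclohexyl gives a 1.7-fold lower number from compound 3 to compound 4 (0.22 log units; within the scatter), so the two groups cannot be told apart at this nitrogen and a readable number no longer stands with 4-fluorobenzyl alone. An aromatic ring in the group therefore does not by itself separate the compounds shown: compound 3 carries one and compound 4 does not, yet both give readable numbers, while the phenyl of compound 1 and the 4-methoxyphenyl of compound 2 both stay at a limit. Cyclohexyl also gives an at least 4.4-fold lower number from compound 2 to compound 4 (0.64 log units; beyond the scatter) and an at least 4.4-fold lower number from compound 1 to compound 4 (0.64 log units; beyond the scatter), and the full size of these two steps cannot be read: the limit of > 100000 nM in this assay, at which 2 of the 4 values shown sit.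

As far as these compounds go, whether an open chain such as n-butyl, a plain benzyl without the fluorine, or a cyclohexyl bearing an amine or a carboxylic acid would fit this same pattern stays open. The shared core is the same in all four compounds, so the compounds shown cannot tell whether these steps would hold on any other core.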